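The source may report more compounds than this note shows. Statements on the series, on what has been measured and on what is new or still open speak of the compounds shown alone.

Compound 1, `CCC(C)NC(=C\C(=O)/C=C/c1ccc(O)c(OC)c1)/C=C/c1ccc(O)c(OC)c1`, gives 91% in a functional assay on Caco-2 cells (Homo sapiens), read by fluorescence, tested at 1 uM; a higher number here means a weaker effect of the compound at the concentration tested, a lower number a stronger effect.
Compound 2, `COc1cc(/C=C/C(=O)/C=C(/C=C/c2ccc(O)c(OC)c2)NCC(C)C)ccc1O`, gives 91% in this assay.

Compound 2 stands level with compound 1 at the digits shown: the one measured step, no change at the digits printed from compound 1 to compound 2 (within the scatter), lies within the usual scatter. Compound 3, `CCCCNC(=C\C(=O)/C=C/c1ccc(O)c(OC)c1)/C=C/c1ccc(O)c(OC)c1`, has not yet been measured. It differs from compound 2 in one place: propyl in place of isopropyl on a saturated chain carbon bound to an amine nitrogen. For the measured compounds named here, only one measured step bears on this, the change from sec-butyl to isobutyl on the amine nitrogen, and it produced no movement beyond the scatter. The present change is again a rearrangement of the same carbons on the group attached to the amine nitrogen, so a step of about no change at the digits printed from compound 2 to compound 3 (within the scatter) is expected, that is none beyond the scatter. Compound 3 is therefore estimated to give 91% in this assay, with a likely range from 80% to 100%.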

Compound 3, a percentage reported as activity, at one concentration (the size of the read-out at that concentration, not a potency): 91%
Compound 3: middle estimate and measured number agree at the digits printed, and the stated range covers the measured number.
By their numbers in this assay, from the lowest: compounds 1, 2 and 3 (each within the scatter of the next).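

In this assay, the unbranched butyl on the amine nitrogen can now be set against both branched groups, giving no change at the digits printed from compound 2 to compound 3 (within the scatter) and no change at the digits printed from compound 1 to compound 3 (within the scatter) as its two steps. The earlier pair compared only two branched groups, whereas these steps show that, among these three groups, losing the branch altogether leaves the read-out as level as moving it did. Nothing available explains why the read-out stays level at this position.

As far as these compounds go, whether the same holds for a smaller group such as methyl, a longer chain such as octyl, a ring such as cyclohexyl, or a chain ending in a carboxylic acid remains open. A reading at one concentration also leaves open how the effects of these compounds compare at other concentrations.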